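The compounds below may be only part of what the source reports. "The series", "measured", "known", "first", "only" and "open" are said of these compounds alone.

Measured in a functional assay on Jurkat cells (Homo sapiens); on this read-out higher numbers stand for weaker inhibition and lower numbers for stronger inhibition:
- compound 1 `C[C@H](NC(=O)C(=O)NCc1ccc(Cl)cc1)C(=O)N[C@@H](CC(=O)O)C(=O)COc1c(F)c(F)cc(F)c1F` gives 8.4 nM
- compound 2 `C[C@H](NC(=O)C(=O)Nc1cccnc1N(C)C)C(=O)N[C@@H](CC(=O)O)C(=O)COc1c(F)c(F)cc(F)c1F` gives 27 nM
- compound 3 `C[C@H](NC(=O)C(=O)NCC1(c2ccccc2)CC1)C(=O)N[C@@H](CC(=O)O)C(=O)COc1c(F)c(F)cc(F)c1F` gives 27 nM

Compound 3 stands level with compound 2, and both carry a higher number than compound 1. The two steps up from compound 1 are modest: a 3.2-fold higher number from compound 1 to compound 3 (0.51 log units; beyond the scatter) and a 3.2-fold higher number from compound 1 to compound 2 (0.51 log units; beyond the scatter). The remaining comparison, no change at the digits printed from compound 2 to compound 3 (within the scatter), shows two quite different groups giving the same number.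

Next is compound 4 `Cc1ccccc1CNC(=O)C(=O)N[C@@H](C)C(=O)N[C@@H](CC(=O)O)C(=O)COc1c(F)c(F)cc(F)c1F`, with 2-methylphenyl in place of 1-phenylcyclopropyl on a saturated chain carbon bound to an amide-type nitrogen.

The closest guide is the step at this same place, a 3.2-fold higher number from compound 1 to compound 3 (0.51 log units; beyond the scatter), where 1-phenylcyclopropyl replaced 4-chlorophenyl. Compound 4 again has a substituted phenyl there, so part of that step may be recovered in this assay. For the measured compounds named here, no measured compound carries 2-methylphenyl, and the argument rests on compound 1 alone. A small move toward a lower number is therefore expected, not clearly beyond the scatter. The expected change is a 1.8-fold lower number from compound 3 to compound 4 (0.26 log units; within the scatter). For compound 4 the estimated value is 15 nM, with an expected range from 6 nM to 40 nM.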

Compound 4, half-maximal inhibitory concentration: 52 nM
Compound 4: the middle estimate sits 3.5-fold (0.54 log units) below what was measured; measured number outside the range, above it.
By their numbers in this assay, from the lowest: compound 1; then compounds 2, 3 and 4 (each within the scatter of the next).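

In this assay, a substituted phenyl on a saturated chain carbon bound to an amide-type nitrogen does not by itself keep the number of compound 1: with 2-methylphenyl in place of 4-chlorophenyl there is a 6.2-fold higher number from compound 1 to compound 4 (0.79 log units; beyond the scatter). Set against the other two groups, the new one gives a 1.9-fold higher number from compound 3 to compound 4 (0.28 log units; within the scatter) and, with 2-methylbenzyl in place of 2-(dimethylamino)pyridin-3-yl on an amide-type nitrogen, a 1.9-fold higher number from compound 2 to compound 4 (0.28 log units; within the scatter), so these data do not separate compound 2, compound 3 and compound 4. Among the four compounds, only the 4-chlorobenzyl group of compound 1 stands apart from the rest, while three quite different groups, one of them without a methylene link to the amide-type nitrogen, fall together.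

Nothing available explains this grouping. From the compounds shown here alone, whether the step from 4-chlorophenyl to 2-methylphenyl belongs to the chlorine or to the place of the substituent on the phenyl stays open, and a 4-methylphenyl or 2-chlorophenyl group at this same place would tell the two apart.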